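Naphthyl to nitrophenyl at the ether of the ketone

This account rests on a few compounds, and the source may have more. Where it says the series, first, only, none or still open, it means among the compounds named here.

Measured compounds in this study:
compound 1, `CC(C)[C@H](NC(=O)COc1cccc2ccccc12)C(=O)N[C@@H](CC(=O)O)C(=O)COc1cccc2ccccc12`, > 100000 nM
compound 2, `CC(C)[C@H](NC(=O)COc1cccc2ccccc12)C(=O)N[C@@H](CC(=O)O)C(=O)COc1ccc(-c2ccccc2)cc1`, 87900 nM
compound 3, `CC(C)[C@H](NC(=O)COc1cccc2ccccc12)C(=O)N[C@@H](CC(=O)O)C(=O)COc1ccc(Oc2ccccc2)cc1`, 12700 nM

The three measured compounds share one core and differ only in the aryl group on the oxygen of the ketone side chain. In a functional assay on Jurkat cells (Homo sapiens) (a lower number here means a stronger inhibitor, a higher number a weaker inhibitor), compound 1 gives > 100000 nM, which is a limit of the assay and not a number (the limit of > 100000 nM in this assay, at which 1 of the 3 values shown sits). Compound 2 and compound 3 give numbers, and the step of a 6.9-fold lower number from compound 2 to compound 3 (0.84 log units; beyond the scatter) is the only one in this set that reaches beyond the scatter.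

The unmeasured compound 4, `CC(C)[C@H](NC(=O)COc1cccc2ccccc12)C(=O)N[C@@H](CC(=O)O)C(=O)COc1ccccc1[N+](=O)[O-]`, differs from compound 1 by 2-nitrophenyl in place of naphthalen-1-yl on an oxygen on a saturated carbon. The step of an at least 1.1-fold lower number from compound 1 to compound 2 (0.05 log units; that floor lies within the scatter) is the one that bears on this change, since it exchanges the same naphthalen-1-yl at the same place, and it is only a floor that lies within the scatter. Within the data shown here, no measured step introduces a nitro group or a 2-substituted phenyl, so the size of the change for compound 4 cannot be read from a matched example.

Among the measured compounds shown here, with compound 1 standing only at a limit and the single comparable step uninformative, compound 4 is expected to land near the region of compound 2, a step of an at least 1.2-fold lower number from compound 1 to compound 4 (0.09 log units; that floor lies within the scatter), with compound 4 estimated at 80000 nM within a range from 20000 nM to 300000 nM.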

Compound 4, half-maximal inhibitory concentration: > 100000 nM
Compound 4 gave a limit, no number; the forecaster's own chance of this, stated with the estimate: 45%; middle value at least 1.2-fold (0.09 log units) from the limit.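

In this assay compound 4 gives > 100000 nM, which is a limit of the assay and not a number: the limit of > 100000 nM in this assay, at which 2 of the 4 values shown sit. The step between compound 1 and compound 4 cannot be read, as both ends are limits, so nothing can be said about how 2-nitrophenyl and naphthalen-1-yl compare on this oxygen. Against 4-phenylphenyl at the same place, 2-nitrophenyl gives an at least 1.1-fold higher number from compound 2 to compound 4 (0.05 log units; that floor lies within the scatter), so this floor does not separate the two groups, and the new result adds only that a single aromatic ring carrying a nitro group does not bring the shared core to a readable number here, while compound 2 and compound 3 remain the only compounds of the four with one.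

The compounds shown leave open whether plain phenyl, or a phenyl carrying an amine or a carboxylic acid in place of the nitro group, would give a number at this place. They also leave open how far compound 1 and compound 4 lie from each other, and whether the phenoxy group of compound 3 could be extended further with a longer chain.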